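Benzylidene series: compound 1 to compound 4 in growth inhibition

The compounds below may be only part of what the source reports. "The series", "measured", "known", "first", "only" and "open" are said of these compounds alone.

Of the compounds shown here, three have been measured in a functional assay on DU-145 cells (Homo sapiens) for inhibition, read by trypan blue exclusion, with a stated time of 96 h; on this read-out higher numbers stand for weaker inhibition of growth and lower numbers for stronger inhibition of growth. Compound 1 `O=C(/C(=C\c1ccccc1F)S(=O)(=O)c1ccc(Br)cc1)c1ccc(Cl)cc1` gives 25000 nM and stands highest of the three numbers. Compound 3 `COc1ccc(S(=O)(=O)/C(=C/c2ccc(Br)cc2)C(=O)c2ccc(Br)cc2)cc1` gives 6000 nM, a lower number than compound 1, with the gap between them beyond the scatter. Compound 2 `O=C(O)c1ccc(C(=O)/C(=C\c2ccc(Cl)c([N+](=O)[O-])c2)SCc2ccc(Br)cc2)cc1` gives 500 nM, the lowest of the three, and its gap to compound 1 is also beyond the scatter. Among the compounds with values here, no two measured compounds differ in one place only, so no single-change step can be read off directly.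

Compound 4 `O=C(/C(=C\c1c(O)cc(O)cc1O)S(=O)(=O)c1ccc(Br)cc1)c1ccc(Cl)cc1` is not yet measured. It differs from compound 1 as follows: 2,4,6-trihydroxyphenyl in place of 2-fluorophenyl on a double-bonded chain carbon bound to a double-bonded chain carbon. Three hydrogen-bond donors and three acceptors enter where none were present, on a double-bonded chain carbon bound to a double-bonded chain carbon; the rest of the shared core is unchanged.

With no step of this kind in the measured set, the expectation rests on compound 1 alone. A moderate move toward a lower number is expected for the step of a 2.5-fold lower number from compound 1 to compound 4 (0.40 log units; beyond the scatter) in this assay, though a result within the scatter of compound 1 cannot be ruled out. Compound 4 is therefore estimated at 10000 nM, with a range from 2500 nM to 40000 nM.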

Compound 4, concentration for 50% growth inhibition: > 100000 nM
Compound 4: no number, only a limit; the forecaster's own chance of this, stated with the estimate: 15%; middle value at least 10-fold (1.00 log units) away from the limit.
By their numbers in this assay, from the lowest: compound 2; then compound 3; then compound 1. At a limit, above all of these: compound 4.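

In this assay compound 4 gives a limit and not a number: the limit of > 100000 nM in this assay, at which 1 of the 4 values shown sits. The exchange of 2-fluorophenyl for 2,4,6-trihydroxyphenyl on a double-bonded chain carbon bound to a double-bonded chain carbon gives an at least 4.0-fold higher number from compound 1 to compound 4 (0.60 log units; beyond the scatter), which is the only single-place step among the compounds shown and shows that this place is sensitive to the group it carries. The step runs toward weaker inhibition of growth, so at this place, on the core of compound 1, the entry of 3 hydrogen-bond donors and 3 hydrogen-bond acceptors with the 2,4,6-trihydroxyphenyl group comes with a loss of growth inhibition rather than a gain.

The compounds shown do not separate the loss of the fluorine from the entry of the hydroxyl groups, and they leave open how a single hydroxyl, a methoxy group or an amine at this place would read. From the compounds shown here alone, compound 2 and compound 3 differ from compound 1 in more than one place, so steps to them cannot be read, and the reach of this result beyond the core of compound 1 stays unknown.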